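A ring swap and its expected effect on growth inhibition

A few compounds are considered here, and "the series" means these few. Any claim that something is new, unique, unknown or untested is made for them only; others in the source may bear on it.

Of the compounds shown here, three built on one shared core have been tested in a functional assay on cells (Cancer cell lines, Homo sapiens) for cytotoxicity, read by sulforhodamine B assay, with a stated time of 48 h; a higher number here means a weaker inhibitor of growth, a lower number a stronger inhibitor of growth. Compound 1 `NS(=O)(=O)c1ccc(-n2nc(-c3ccc(Cl)cc3)cc2-c2cc(O)ccc2O)cc1` gives 17800 nM. Compound 3 `NS(=O)(=O)c1ccc(-n2nc(-c3ccc(Cl)cc3)cc2C2=CC(=O)C=CC2=O)cc1` gives 23700 nM; the step of a 1.3-fold higher number from compound 1 to compound 3 (0.12 log units; within the scatter) comes from the change (a group of 8 heavy atoms (6 carbon, 2 oxygen; one six-membered non-aromatic ring of carbon only) in place of a group of 8 heavy atoms (6 carbon, 2 oxygen; one six-membered aromatic ring of carbon only), on an aromatic carbon). Compound 2 `CC(=O)NS(=O)(=O)c1ccc(-n2nc(-c3ccccc3)cc2-c2cc(O)ccc2O)cc1` gives 90400 nM, the highest of the three numbers; the difference between the core of compound 2 and the core of compound 1 is not broken down here.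

Compound 4 `CC(=O)NS(=O)(=O)c1ccc(-n2nc(-c3ccccc3)cc2C2=CC(=O)C=CC2=O)cc1` has not yet been measured. It differs from compound 2 by a group of 8 heavy atoms (6 carbon, 2 oxygen; one six-membered non-aromatic ring of carbon only) in place of a group of 8 heavy atoms (6 carbon, 2 oxygen; one six-membered aromatic ring of carbon only), on an aromatic carbon. This is the same kind of change as from compound 1 to compound 3, though the surroundings are not identical: in compound 2 the place is next to the ring atom that bears a large group and two ring bonds from the ring atom that bears a phenyl group, whereas in compound 1 those ring atoms bear a 4-sulfamoylphenyl group and a 4-chlorophenyl group. The expectation rests on that single measured example, a 1.3-fold higher number from compound 1 to compound 3 (0.12 log units; within the scatter), which stayed within the scatter. The step from compound 2 to compound 4 is therefore expected to be small, a 1.2-fold higher number from compound 2 to compound 4 (0.09 log units; within the scatter). Compound 4 is estimated to give about 110000 nM, with a likely range from 45000 nM to 280000 nM.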

Compound 4, concentration for 50% growth inhibition: 100000 nM
Estimate against measurement, compound 4: 1.1-fold (0.04 log units) above, within the range that was stated.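

In this assay, putting the non-aromatic ring in place of the 2,5-dihydroxyphenyl group gives a 1.1-fold higher number from compound 2 to compound 4 (0.04 log units; within the scatter), so the same change has now been measured on two cores, and the two results agree: the same change on two cores in this assay, a 1.3-fold higher number (0.12 log units; within the scatter) from compound 1 to compound 3 and a 1.1-fold higher number (0.04 log units; within the scatter) from compound 2 to compound 4, 1.2-fold (0.08 log units) apart, within the scatter of two such steps. In both pairs, the change leaves the number where it was within the scatter, and the outcome carries over from the core of compound 1 to the core of compound 2. For the compounds shown here, this rests on only two pairs, both with weak growth inhibition, so it does not show that the change would be as small on other cores, and it does not explain why so little happens.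

The compounds shown leave open whether the two ring groups would still match on a core where growth inhibition is much stronger. As far as these compounds go, it is also open how the ring would behave if an amine or a methoxy group stood in place of the hydroxyl groups.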